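Swapping nitrile for sulfamoyl on compound 3

This account rests on a few compounds, and the source may have more. Where it says the series, first, only, none or still open, it means among the compounds named here.

Measured so far in an ADME assay (liver) for metabolic stability, with Liver microsome (Homo sapiens) as the target, using microsomes; on this read-out higher numbers stand for fast clearance and lower numbers for slow clearance:
- compound 1 `NS(=O)(=O)c1ccc(OCCCN2CCC(C(O)(c3cccc(F)c3)c3nccs3)CC2)cc1`: 50 mL/min/kg
- compound 2 `N#Cc1ccc(OCCCN2CCC(C(O)(c3cccc(F)c3)c3nccs3)CC2)cc1`: 69 mL/min/kg
- compound 3 `N#Cc1ccc(OCCCN2CCC(C(O)(c3ccccn3)c3nccs3)CC2)cc1`: 20 mL/min/kg

Of these three, compound 3 has the lowest clearance, clearly under both neighbours. It got there by exchanging a 3-fluorophenyl group for a pyridin-2-yl group, which is a 3.5-fold lower number from compound 2 to compound 3 (0.54 log units; beyond the scatter). That step changes a different part of the molecule, so it says little about the next one.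

The next compound is compound 4 `NS(=O)(=O)c1ccc(OCCCN2CCC(C(O)(c3ccccn3)c3nccs3)CC2)cc1`, not yet measured. It keeps everything in compound 3 except one group, with sulfamoyl in place of cyano on an aromatic carbon.

The same exchange has been measured once, in the opposite direction and on the 3-fluorophenyl version of the molecule: a 1.4-fold higher number from compound 1 to compound 2 (0.14 log units; within the scatter). Read backwards, this single pair suggests that sulfamoyl brings a slightly lower number, or no real change. The pyridin-2-yl version may behave differently, and no data test that yet. No step beyond the scatter is therefore expected in this assay, and the estimate is a 1.3-fold lower number from compound 3 to compound 4 (0.12 log units; within the scatter). For compound 4 the expected value is 15 mL/min/kg, with an estimated range from 8 mL/min/kg to 28 mL/min/kg.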

Compound 4, clearance: 17 mL/min/kg
Compound 4: middle estimate off by 1.1-fold (0.05 log units), on the low side, within the range that was stated.
By their numbers in this assay, from the lowest: compounds 4 and 3 (each within the scatter of the next); then compounds 1 and 2 (each within the scatter of the next).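

In this assay, the sulfamoyl for cyano exchange on the pyridin-2-yl version of the molecule gives a 1.2-fold lower number from compound 3 to compound 4 (0.07 log units; within the scatter), so this position has now shown no real change on a second core. The earlier pair alone could not show whether that near-silence was particular to the 3-fluorophenyl version, but the two readings agree: the same change on two cores in this assay, a 1.4-fold higher number (0.14 log units; within the scatter) from compound 1 to compound 2 and a 1.2-fold higher number (0.07 log units; within the scatter) from compound 4 to compound 3, 1.2-fold (0.07 log units) apart, within the scatter of two such steps

The pyridin-2-yl for 3-fluorophenyl exchange also keeps its size when sulfamoyl replaces cyano, with a 2.9-fold lower number from compound 1 to compound 4 (0.47 log units; beyond the scatter), so the two changes appear to act independently in these four compounds: the same change on two cores in this assay, a 3.5-fold lower number (0.54 log units; beyond the scatter) from compound 2 to compound 3 and a 2.9-fold lower number (0.47 log units; beyond the scatter) from compound 1 to compound 4, 1.2-fold (0.07 log units) apart, within the scatter of two such steps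

The compounds shown cover only cyano and sulfamoyl at this position, which leaves open whether a carboxylic acid or an amine on the same aromatic carbon would also leave the clearance number within the scatter. They also leave open whether the drop seen with pyridin-2-yl would appear with an unsubstituted phenyl group in that place, and whether either result would hold with a longer chain between the oxygen and the ring nitrogen.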